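Aryl swap on the ring nitrogen: compound 2 to compound 3

The source may report more compounds than this note shows. Statements on the series, on what has been measured and on what is new or still open speak of the compounds shown alone.

Of the compounds shown here, two have been measured. Compound 1 `COc1ccc(-n2cc(COc3ccc4oc(=O)ccc4c3)nn2)cc1` gives 46800 nM in a functional assay on A549 cells (Homo sapiens) for cytotoxicity, read by MTT assay, with a stated time of 48 h; a lower number here means a stronger inhibitor, a higher number a weaker inhibitor. Compound 2 `O=c1ccc2cc(OCc3cn(-c4ccc([N+](=O)[O-])cc4)nn3)ccc2o1` gives 33600 nM in this assay. Compound 2 holds the lowest of the two numbers, with compound 1 nearest; the step of a 1.4-fold lower number from compound 1 to compound 2 (0.14 log units; within the scatter) lies within the scatter, so no order between the two can be read. Compound 3 `N#Cc1ccccc1-n1cc(COc2ccc3oc(=O)ccc3c2)nn1` is not yet measured. It differs from compound 2 by 2-cyanophenyl in place of 4-nitrophenyl on an aromatic nitrogen. Going by the values given here, only one measured step bears on this: a 1.4-fold lower number from compound 1 to compound 2 (0.14 log units; within the scatter), which exchanged the group on the phenyl and stayed within the scatter. Among the compounds with values here, no measured step covers exchange of the phenyl itself for another, so the expectation rests on that single step. Expected for this change: a 1.1-fold higher number from compound 2 to compound 3 (0.05 log units; within the scatter), that is no shift beyond the scatter. Compound 3 is therefore estimated at 38000 nM in this assay, with a range from 14000 nM to 100000 nM.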

Compound 3, half-maximal inhibitory concentration: 12600 nM
For compound 3 the middle estimate is 3.0-fold (0.48 log units) above the measured one; the whole stated range lies above it.
By their numbers in this assay, from the lowest: compound 3; then compounds 2 and 1 (each within the scatter of the next).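

In this assay, replacing the whole aryl group on the aromatic nitrogen gives a shift beyond the scatter, with a 2.7-fold lower number from compound 2 to compound 3 (0.43 log units; beyond the scatter) and a 3.7-fold lower number from compound 1 to compound 3 (0.57 log units; beyond the scatter), whereas the exchange of nitro for methoxy on the phenyl, a 1.4-fold lower number from compound 1 to compound 2 (0.14 log units; within the scatter), stayed within it. This position therefore responds to the aryl group it carries, and compound 3 stands lowest of the three, with both of its steps beyond the scatter. No evidence at hand accounts for this shift.

Both the nitrile and its place on the phenyl differ in 2-cyanophenyl, so the two are not separated; a 4-cyanophenyl comparison would address that. Also open, as far as these compounds go, is how an unsubstituted phenyl, or a phenyl carrying an amine or a carboxylic acid, would stand in this assay.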